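The source may report more compounds than this note shows. Statements on the series, on what has been measured and on what is new or still open speak of the compounds shown alone.

- compound 1 `CCOC(=O)c1c(C)nc(-c2cccc(C#N)c2)n1OCc1ccc(F)cc1`: 5880 nM
- compound 2 `CCOC(=O)c1c(C)nc(-c2cccc(C#N)c2)n1OCc1ccc(Cl)cc1`: 6830 nM

In a functional assay on a cell-free system (plasma, Oryctolagus cuniculus) for inhibition, with stated times of 5 min, 1 min and 6 min (on this read-out higher numbers stand for weaker inhibition and lower numbers for stronger inhibition), compound 2 gives 6830 nM, level with compound 1 within the scatter. Compound 3 `CCOC(=O)c1c(C)nc(-c2cccc(C#N)c2)n1OCc1ccc([N+](=O)[O-])cc1` brings (nitro in place of chloro on an aromatic carbon), nitro in place of chloro on an aromatic carbon, para to a large group. For the measured compounds named here, one measured step bears on this: a 1.2-fold higher number from compound 1 to compound 2 (0.07 log units; within the scatter), with chloro in place of fluoro on an aromatic carbon. Going by the values given here, no measured compound carries nitro, so this small step is only a weak guide. The estimated outcome is a 1.1-fold lower number from compound 2 to compound 3 (0.06 log units; within the scatter), with no shift expected beyond the scatter. For compound 3 the expected value is 6000 nM, with an estimated range of 2500 nM to 14000 nM.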

Compound 3, half-maximal inhibitory concentration: 8750 nM
Compound 3: middle estimate off by 1.5-fold (0.16 log units), on the low side; the range from low to high includes it.
By their numbers in this assay, from the lowest: compounds 1, 2 and 3 (each within the scatter of the next).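

With nitro on the aromatic carbon para to a large group, the step is a 1.3-fold higher number from compound 2 to compound 3 (0.11 log units; within the scatter) in this assay and the comparison with the fluoro compound gives a 1.5-fold higher number from compound 1 to compound 3 (0.17 log units; within the scatter). Both steps lie within the scatter, so this place has now taken fluoro, chloro and nitro, a group of three heavy atoms with two hydrogen-bond acceptors, without a readable change in inhibition. Nothing at hand speaks to why this is so.

On these data alone, whether an amine or a carboxylic acid at this place would shift the number beyond the scatter remains open. So does the effect of a longer chain in place of the 4-nitrobenzyl group.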